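The compounds below may be only part of what the source reports. "The series", "measured", "known", "first", "only" and "open" are said of these compounds alone.

Measured compounds in an ADME assay on HUVEC cells (Homo sapiens) for antiproliferative activity, read by MTT assay, with a stated time of 48 h; on this read-out higher numbers stand for weaker inhibition and lower numbers for stronger inhibition:
- compound 1 `N#CC1=C(N)Oc2c(c3nc4ccccc4nc3c3ccccc23)C12C(=O)N(Cc1cnnn1-c1cccc(S(N)(=O)=O)c1)c1ccccc12`: compound 1 gives 38600 nM
- compound 2 `Cc1cc(C)cc(-n2nncc2CN2C(=O)C3(C(C#N)=C(N)Oc4c3c3nc5ccccc5nc3c3ccccc43)c3ccccc32)c1`: compound 2 gives only the limit > 50000 nM
- compound 3 `Cc1ccccc1-n1nncc1CN1C(=O)C2(C(C#N)=C(N)Oc3c(N)cc4nc5ccccc5nc4c32)c2ccccc21`: compound 3 gives only the limit > 50000 nM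

Compound 3 stands at the upper edge of the numbers shown: its value is a limit of the assay, not a number, and the same holds for compound 2. Going by the values given here, compound 1 is the only member with a numerical value, and it is itself a weak one. Two of the three values sit at the limit (the limit of > 50000 nM in this assay, at which 2 of the 3 values shown sit), so the series is poorly resolved here.

The unmeasured compound 4 `Cc1ccc(-n2nncc2CN2C(=O)C3(C(C#N)=C(N)Oc4c(N)cc5nc6ccccc6nc5c43)c3ccccc32)cc1Cl` differs from compound 3 in one place, (3-chloro-4-methylphenyl in place of 2-methylphenyl on an aromatic nitrogen).

Among the compounds with values here, one measured step bears on this kind of change, a swap of the aryl group on the aromatic nitrogen: an at least 1.2-fold higher number from compound 1 to compound 2 (0.11 log units; that floor lies within the scatter). That step is a floor only and lies within the scatter, so it gives no direction. Within the data shown here, the change from compound 3 to compound 4 is of the same kind, a substituted phenyl exchanged for another substituted phenyl at the same position, and nothing among the measured compounds suggests a shift beyond the scatter.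

The estimated step that the limit leaves unreadable from compound 3 to compound 4 is therefore expected to be essentially flat. Compound 4 is expected at about 60000 nM, within 25000 nM to 150000 nM, and most likely again reported only as a limit.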

Compound 4, half-maximal inhibitory concentration: > 50000 nM
Compound 4 was reported as a limit; the forecaster's own chance of this, stated with the estimate: 75%; the middle value does not contradict the limit.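

In this assay compound 4 gives > 50000 nM, a limit and not a number. Compound 3 gives > 50000 nM, also a limit, so no step can be read between compound 3 and compound 4. The compounds shown leave open whether 3-chloro-4-methylphenyl in place of 2-methylphenyl on the aromatic nitrogen changes the read-out at all.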